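Replacing a nitro group with fluoro

The compounds below may be only part of what the source reports. "The series", "measured", "known", "first", "only" and "open" are said of these compounds alone.

In a functional assay on A549 cells (Homo sapiens) for antiproliferative activity, read by MTT assay, with a stated time of 24 h (on this read-out lower numbers stand for stronger inhibition and higher numbers for weaker inhibition), compound 1 `COc1ccc(S(=O)(=O)n2c(-c3cn(-c4ccccc4)nc3-c3ccc(F)cc3)nc3ccccc32)cc1` gives 350 nM and compound 2 `O=[N+]([O-])c1ccc(S(=O)(=O)n2c(-c3cn(-c4ccccc4)nc3-c3ccc(F)cc3)nc3ccccc32)cc1` gives 1030 nM, the higher of the two numbers and so the weaker inhibition. Compound 3 `O=S(=O)(c1ccc(F)cc1)n1c(-c2cn(-c3ccccc3)nc2-c2ccc(F)cc2)nc2ccccc21` carries fluoro in place of nitro on an aromatic carbon, para to a large group: fluoro in place of nitro on an aromatic carbon. Going by the values given here, the one measured step at this place, nitro in place of methoxy, is modest: a 2.9-fold higher number from compound 1 to compound 2 (0.47 log units; beyond the scatter). No measurement with fluoro exists yet, so a similarly modest move toward lower numbers is expected, an estimated 2.1-fold lower number from compound 2 to compound 3 (0.31 log units; beyond the scatter). The estimate for compound 3 is 500 nM, within a range of 200 nM to 1200 nM.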

Compound 3, half-maximal inhibitory concentration: 2370 nM
Compound 3: middle estimate off by 4.7-fold (0.68 log units), on the low side; the measured number lies above the stated range.
By their numbers in this assay, from the lowest: compound 1; then compound 2; then compound 3.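

Swapping nitro for fluoro in this assay gives a 2.3-fold higher number from compound 2 to compound 3 (0.36 log units; beyond the scatter), and swapping methoxy for fluoro gives a 6.8-fold higher number from compound 1 to compound 3 (0.83 log units; beyond the scatter). Nitro therefore does not mark the weak end of this position: among these three groups, the order from the lowest number is methoxy, nitro, fluoro. Nothing measured here explains this order.

Going by these compounds, it remains open whether an amine, a hydroxyl or a longer chain such as ethoxy at this place would give a lower number than methoxy. The same order may or may not hold with other groups elsewhere on the shared core.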